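Ring swap on the benzyl arm: cytotoxicity in mouse fibroblasts

The compounds below may be only part of what the source reports. "The series", "measured", "known", "first", "only" and "open" are said of these compounds alone.

Compound 1 `OC[C@H]1O[C@@H](n2cnc3c(NCc4ccccc4Cl)ncnc32)[C@H](O)[C@@H]1O` in an ADME assay on NIH3T3 cells (Mus musculus) for cytotoxicity, with a stated time of 72 h (a lower number here means a stronger inhibitor, a higher number a weaker inhibitor), gives > 166000 nM, which is a limit of the assay and not a number. Compound 2 `COc1cccc(CNc2ncnc3c2ncn3[C@@H]2O[C@H](CO)[C@@H](O)[C@H]2O)c1` gives > 166000 nM, again only a limit. Compound 3 `OC[C@H]1O[C@@H](n2cnc3c(NCc4cc(F)cc(F)c4)ncnc32)C(O)C1O` gives > 166000 nM, also a limit.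

Compound 2 therefore stands at the limit of this assay, with no numerical value to compare. Among the compounds with values here, the only single-point step that reaches it is a step that the two limits leave unreadable from compound 1 to compound 2, which cannot be read because of the limit of > 166000 nM in this assay, at which 3 of the 3 values shown sit.

Compound 4 `OC[C@H]1O[C@@H](n2cnc3c(NCc4ccc(F)c(Cl)c4)ncnc32)[C@H](O)[C@@H]1O` differs from compound 2 by 3-chloro-4-fluorophenyl in place of 3-methoxyphenyl on a saturated chain carbon bound to a nitrogen on an aromatic ring. Within the data shown here, no measured step shows a readable change, so none beyond the scatter is expected. Compound 4 is expected to give 200000 nM, with a range from 100000 nM to 500000 nM. The expected step is a step that the limit leaves unreadable from compound 2 to compound 4, most likely reported only as a limit.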

Compound 4, half-maximal inhibitory concentration: > 166000 nM
Compound 4 was reported as a limit; the forecaster's own chance of this, stated with the estimate: 85%; the middle value is on the limit's open side.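

The steps to compound 4 from compound 1 and from compound 2 cannot be read, because all these results are limits and not numbers: the limit of > 166000 nM in this assay, at which 4 of the 4 values shown sit.

The compounds shown leave open whether any ring on this benzyl arm gives a measurable number in this assay.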